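Working notes: from compound 2 toward compound 3

The source may hold more compounds than are shown below. What is called first, only, known or untested is meant among the compounds shown, and "the series" means these compounds.

Measured so far:
compound 1, `Cc1c(-c2ccc(N(C)C)cc2)oc2ccccc2c1=O`: 104 ug/mL
compound 2, `Cc1ccccc1-c1oc2ccccc2c(=O)c1C`: 156 ug/mL

In a functional assay, read by spectrophotometry, with a stated time of 20 min (a higher number here means a weaker inhibitor, a lower number a stronger inhibitor), compound 1 gives 104 ug/mL. Compound 2 gives 156 ug/mL in this assay. The two numbers lie within the scatter of each other, so compound 2 cannot be set apart from compound 1 on these data; both sit at the weak end of what this assay resolves.

Compound 3, `Cc1c(-c2ccccc2Cl)oc2ccccc2c1=O`, has not been measured. It differs from compound 2 by chloro in place of methyl on an aromatic carbon. For the measured compounds named here, no measured pair shows what this exchange does here, and the two measured compounds vary at several places at once, so no guide exists for it. The step of a 1.0-fold lower number from compound 2 to compound 3 (0.02 log units; within the scatter) is expected to stay within the scatter, with no direction favoured. Compound 3 is estimated at 150 ug/mL, between 70 ug/mL and 320 ug/mL.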

Compound 3, half-maximal inhibitory concentration: 192 ug/mL
For compound 3 the middle estimate is 1.3-fold (0.11 log units) below the measured one; the measured number falls inside the stated range.
By their numbers in this assay, from the lowest: compounds 1, 2 and 3 (each within the scatter of the next).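

In this assay, for the compounds shown here, the exchange of methyl for chloro on an aromatic carbon, ortho to a large group, gives a 1.2-fold higher number from compound 2 to compound 3 (0.09 log units; within the scatter) and is the first change confined to one place. At this position, the two groups cannot be told apart on these data, a result the earlier pair could not give because compounds 1 and 2 vary at several places at once. No measurement available here bears on the reason for this result.

As far as these compounds go, it remains open whether an amine, a carboxylic acid or a methoxy group on this same aromatic carbon would give a step beyond the scatter. Also open, from the compounds shown here alone, is whether a longer chain in place of the methyl on the shared core would do so.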